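Notes on the step from compound 2 to compound 4

A few compounds are considered here, and "the series" means these few. Any claim that something is new, unique, unknown or untested is made for them only; others in the source may bear on it.

Values in a functional assay on Ehrlich cells (Mus musculus) for cytotoxicity, read by trypan blue exclusion, with a stated time of 2 h; on this read-out lower numbers stand for stronger inhibition and higher numbers for weaker inhibition:
- compound 1 `N#CC1=C(N)N(c2ccc(S(N)(=O)=O)cc2)C2=C(C(=O)CCC2)C1c1ccc(Cl)cc1Cl`: 25 ug/mL
- compound 2 `N#CC1=C(NC(=O)c2ccccc2)N(c2ccc(S(N)(=O)=O)cc2)C2=C(C(=O)CCC2)C1c1ccc(Cl)cc1Cl`: 10 ug/mL
- compound 3 `CN(C)c1ccc(/C=C/C=N/C2=C(C#N)C(c3ccc(Cl)cc3Cl)C3=C(CCCC3=O)N2c2ccc(S(N)(=O)=O)cc2)cc1`: > 100 ug/mL (a limit)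

Compound 2 gives the lower of the two actual numbers, 10 ug/mL. Among the measured compounds shown here, compound 3 gives only a limit, > 100 ug/mL, so it sets no size for a step.

Compound 4 `CCO/C=N/C1=C(C#N)C(c2ccc(Cl)cc2Cl)C2=C(CCCC2=O)N1c1ccc(S(N)(=O)=O)cc1` differs from compound 2 on a double-bonded ring carbon: a group of 5 heavy atoms (3 carbon, 1 nitrogen, 1 oxygen; no ring) in place of a group of 9 heavy atoms (7 carbon, 1 nitrogen, 1 oxygen; one six-membered aromatic ring of carbon only), on a double-bonded ring carbon. For the measured compounds named here, the one measured step bearing on this is a 2.5-fold lower number from compound 1 to compound 2 (0.40 log units; beyond the scatter), where benzoyl stands in place of hydrogen on an amine nitrogen. Compound 4 lacks that benzoyl too, so a modest step towards a higher number in this assay is expected, similar in size to that one. The group that enters has not been tested in this series, so the expectation is loose. The expected change is a 2.5-fold higher number from compound 2 to compound 4 (0.40 log units; beyond the scatter). For compound 4 the estimate is 25 ug/mL, with an expected range of 10 ug/mL to 80 ug/mL.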

Compound 4, half-maximal inhibitory concentration: > 100 ug/mL
Compound 4: only a limit was reported (the forecaster's own chance of this, stated with the estimate: 15%); at least 4.0-fold (0.60 log units) between middle value and limit.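

In this assay compound 4 gives > 100 ug/mL, which is a limit. Against the benzamido group, the entering group gives an at least 10-fold higher number from compound 2 to compound 4 (1.00 log units; beyond the scatter), and against the plain amine it gives an at least 4.0-fold higher number from compound 1 to compound 4 (0.60 log units; beyond the scatter), so this change on the double-bonded ring carbon does more than undo the benzoyl step: compound 4 also reads weaker than compound 1. Compound 3 and compound 4, which carry different groups on the carbon with a double bond to nitrogen, end at the same assay limit: the limit of > 100 ug/mL in this assay, at which 2 of the 4 values shown sit.

The step from compound 3 to compound 4 cannot be read, as both values are limits. Going by these compounds, it remains open whether the stronger reading of compound 2 depends on the amide link or on its phenyl ring, a question that an acetyl amide or a simple alkyl amine at this position would address.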